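The source may hold more compounds than are shown below. What is called first, only, known or untested is meant among the compounds shown, and "the series" means these compounds.

Measured compounds in a functional assay on MCF7 cells (Homo sapiens) for inhibition, read by MTT assay, with a stated time of 72 h; on this read-out lower numbers stand for stronger inhibition and higher numbers for weaker inhibition:
- compound 1 `O=C(O)CCCCCCC(=O)Nc1ccc(C2=C(c3ccc(O)cc3)C3CC(S(=O)(=O)Oc4ccccc4C(F)(F)F)C2O3)cc1` gives 26100 nM
- compound 2 `O=C(O)CCCCCCC(=O)Nc1ccc(C2=C(c3ccc(O)cc3)C3CC(S(=O)(=O)Oc4ccc(F)cc4)C2O3)cc1` gives 24800 nM
- compound 3 `O=C(O)CCCCCCC(=O)Nc1ccc(C2=C(c3ccc(O)cc3)C3CC(S(=O)(=O)Oc4cccc5ccccc45)C2O3)cc1` gives 4700 nM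

Compound 3 stands lowest of the three numbers. The steps leading to it are a 5.6-fold lower number from compound 1 to compound 3 (0.74 log units; beyond the scatter) and a 5.3-fold lower number from compound 2 to compound 3 (0.72 log units; beyond the scatter), both beyond the scatter, while the step between the two single-ring aryl groups, a 1.1-fold lower number from compound 1 to compound 2 (0.02 log units; within the scatter), lies within the scatter.

Compound 4 `O=C(O)CCCCCCC(=O)Nc1ccc(C2=C(c3ccc(O)cc3)C3CC(S(=O)(=O)Oc4ccc5ccccc5c4)C2O3)cc1` differs from compound 3 only at the oxygen whose other neighbour is the sulfonyl sulfur: naphthalen-2-yl in place of naphthalen-1-yl on an oxygen. The measured steps that touch this oxygen are a 5.6-fold lower number from compound 1 to compound 3 (0.74 log units; beyond the scatter) and a 5.3-fold lower number from compound 2 to compound 3 (0.72 log units; beyond the scatter); each exchanged a single six-membered ring for naphthalen-1-yl, and that exchange produced the whole gain. Among the compounds with values here, no measured pair compares the two naphthyl isomers, so the change in compound 4 keeps the two six-membered aromatic rings and is expected to give no step beyond the scatter, estimated as a 1.2-fold higher number from compound 3 to compound 4 (0.07 log units; within the scatter). Compound 4 is therefore expected at 5500 nM, with a range of 2200 nM to 14000 nM.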

Compound 4, half-maximal inhibitory concentration: 18900 nM
Compound 4: middle estimate off by 3.4-fold (0.54 log units), on the low side, and the stated range ends below it.
By their numbers in this assay, from the lowest: compound 3; then compounds 4, 2 and 1 (each within the scatter of the next).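

In this assay the point of attachment alone counts at this position: on the oxygen whose other neighbour is the sulfonyl sulfur, with the same atoms in both groups, a 4.0-fold higher number from compound 3 to compound 4 (0.60 log units; beyond the scatter) is a step beyond the scatter. The gain seen earlier therefore belongs to naphthalen-1-yl and not to the presence of two six-membered aromatic rings, since a 1.3-fold lower number from compound 2 to compound 4 (0.12 log units; within the scatter) and a 1.4-fold lower number from compound 1 to compound 4 (0.14 log units; within the scatter) both stay within the scatter, leaving naphthalen-2-yl level with the two single-ring aryl groups. Nothing at hand accounts for the gap between the two isomers.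

Open, going by these compounds, is whether a methoxy group on the naphthalen-1-yl ring, or a quinolin-8-yl group in its place, would keep the lower number. Also open, on these data alone, is whether the gap between the isomers persists with a hydroxamic acid in place of the carboxylic acid.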